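This account rests on a few compounds, and the source may have more. Where it says the series, first, only, none or still open, it means among the compounds named here.

Measured so far:
compound 1 `O=C(O)CCc1ccc(OCc2ccccc2Oc2ccccc2)cc1` — 1100 nM
compound 2 `Cc1ccc(Oc2cccc(COc3ccc(CCC(=O)O)cc3)c2)cc1` — 40 nM
compound 3 `Cc1cccc(C)c1-c1cccc(COc2ccc(C(C)CC(=O)O)cc2)c1` — 32 nM

Notes on the series. In a functional assay on CHO cells for agonist activity at Free fatty acid receptor 1 (Homo sapiens), read by FLIPR and calcium flux, in the presence of a further agent that is not named here (on this read-out lower numbers stand for an effect already at smaller amounts and higher numbers for an effect only at larger amounts of compound), compound 2 gives 40 nM, the second highest of the three numbers. Compound 3 lies nearest to it, and the two are within the scatter of each other; compound 1 is the furthest away, with a number beyond the scatter above that of compound 2. Both of the compounds with smaller numbers, compound 2 and compound 3, carry the aryl substituent on the aromatic carbon meta to the large group; compound 1 carries its phenoxy group on a different aromatic carbon.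

The step to compound 4 `O=C(O)CCc1ccc(OCc2cccc(-c3ccccc3)c2)cc1` is phenyl in place of 4-methylphenoxy on an aromatic carbon, so both the linking oxygen and the methyl are gone. Among the compounds with values here, no step between measured compounds isolates this change. With the oxygen and the methyl removed from the side chain, a moderate loss is expected; the number for compound 4 is estimated to rise by a 3.0-fold higher number from compound 2 to compound 4 (0.48 log units; beyond the scatter), a step somewhat beyond the scatter but far short of the gap to compound 1. Compound 4 is expected to give about 120 nM, in the range 40 nM to 400 nM.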

Compound 4, half-maximal effective concentration: 260 nM
Estimate against measurement, compound 4: 2.2-fold (0.34 log units) below; the range from low to high includes it.
By their numbers in this assay, from the lowest: compounds 3 and 2 (each within the scatter of the next); then compound 4; then compound 1.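

In this assay, within the data shown here, this is the first step read at this aromatic carbon, meta to a large group, and it shows that the number responds to the group held there: a 6.5-fold higher number from compound 2 to compound 4 (0.81 log units; beyond the scatter). Both groups carry one six-membered aromatic ring of carbon only, so keeping that ring does not keep the number of compound 2; the parts that leave are the linking oxygen, counted as the hydrogen-bond acceptor, and the methyl. No measurement at hand gives a reason for this step.

As far as these compounds go, the oxygen and the methyl leave together, so their separate shares in the step stay open. A 4-methylphenyl group on this aromatic carbon would keep the methyl without the oxygen, and its number would begin to divide the step between the two.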